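This account rests on a few compounds, and the source may have more. Where it says the series, first, only, none or still open, it means among the compounds named here.

Of the compounds shown here, two have been tested in an ADME assay on HEp-2 cells (Homo sapiens) for cytotoxicity, read by CCK-8 assay, with a stated time of 6 days; on this read-out higher numbers stand for lower toxicity in this test and lower numbers for higher toxicity in this test. Compound 1 `Cc1ccn2c(CCCCO)c(Cn3c(=O)n(C4CC4)c4ccncc43)nc2c1` gives in this assay only a limit of > 100000 nM. Among the compounds with values here, compound 2 `N#Cc1c(Cn2c(=O)n(C3CC3)c3ccncc32)nc2cc(Cl)ccn12` is the sole compound with a numerical value, and in this assay compound 2 gives 22500 nM; compound 2 thus stands as the only fixed point, with the other result being (the limit of > 100000 nM in this assay, at which 1 of the 2 values shown sits). Compound 3 `NC(=O)CCc1c(Cn2c(=O)n(C3CC3)c3ccncc32)nc2cc(Cl)ccn12` has not yet been measured. It differs from compound 2 in one place: 2-carbamoylethyl in place of cyano on an aromatic carbon. Within the data shown here, no step between two measured compounds is available, so an expectation for compound 3 rests on compound 2 alone. The step from compound 2 to compound 3 is expected to be a 2.7-fold higher number from compound 2 to compound 3 (0.43 log units; beyond the scatter), tending toward lower toxicity. Compound 3 is therefore estimated to give about 60000 nM in this assay, with a plausible range from 20000 nM to 200000 nM.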

Compound 3, half-maximal cytotoxic concentration: > 100000 nM
Compound 3: no number, only a limit; the forecaster's own chance of this, stated with the estimate: 40%; middle value at least 1.6-fold (0.22 log units) from the limit.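

In this assay, 2-carbamoylethyl in place of cyano on this aromatic carbon brings an at least 4.4-fold higher number from compound 2 to compound 3 (0.64 log units; beyond the scatter), so the group at this position clearly bears on the read-out, tending toward lower toxicity in this test. Compound 3 gives a limit and not a number, so this step marks only the smallest size the change can have: the limit of > 100000 nM in this assay, at which 2 of the 3 values shown sit.

Of the two groups compared on this shared core, only cyano gives a numerical value. The compounds shown cannot separate the contribution of the terminal amide from that of the chain carrying it, a question that a plain propyl chain, a carboxylic acid on the same chain or a primary amide set directly on the ring carbon would address. On these data alone, how far the true value of compound 3 lies past its limit also stays open.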